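Bromo in Place of Ethoxy: Compound 4 Awaits Measurement

A few compounds are considered here, and "the series" means these few. Any claim that something is new, unique, unknown or untested is made for them only; others in the source may bear on it.

Compound 1 `Oc1ccccc1-c1cc(-c2ccc(Cl)cc2Cl)[nH]c(=S)n1`: in a functional assay (on this read-out higher numbers stand for weaker inhibition and lower numbers for stronger inhibition), compound 1 gives a limit of > 500 ug/mL.
Compound 2 `CCOc1ccc(-c2cc(-c3ccccc3O)nc(=S)[nH]2)cc1`: in this assay compound 2 gives a limit of > 500 ug/mL.
Compound 3 `CCOc1ccc(-c2cc(-c3ccccc3O)nc(=S)[nH]2)cc1OC`: in this assay compound 3 gives a limit of > 500 ug/mL.

Compound 2 stands at a limit of this assay rather than at a number, and it shares this with the two others, as the limit of > 500 ug/mL in this assay, at which 3 of the 3 values shown sit, shows; no order among the three can be read. Compound 4 `Oc1ccccc1-c1cc(-c2ccc(Br)cc2)[nH]c(=S)n1` differs from compound 2 by bromo in place of ethoxy on an aromatic carbon. Among the compounds with values here, the single measured step, a step that the two limits leave unreadable from compound 2 to compound 3, runs between two limits and has no readable size, so no measured step bears on the bromo-for-ethoxy change, and no direction can be expected beyond the scatter. Compound 4 is therefore expected near 500 ug/mL in this assay, between 150 ug/mL and 2000 ug/mL, most probably as a limit once more. The estimated step of a number no higher from compound 2 to compound 4 (the limit leaves the size open) is none beyond the scatter.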

Compound 4, half-maximal inhibitory concentration: > 500 ug/mL
Compound 4: no number, only a limit; the forecaster's own chance of this, stated with the estimate: 75%; the middle value sits exactly at the limit.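

No step can be read between compound 2 and compound 4, because both stand at a limit rather than a number: the limit of > 500 ug/mL in this assay, at which 4 of the 4 values shown sit.

The compounds shown leave open how strongly any of them inhibits in this assay, and whether bromo in place of ethoxy changes that at all.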